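The source may report more compounds than this note shows. Statements on the series, on what has been measured and on what is new or still open speak of the compounds shown alone.

Compound 2 `CCCCCCCCCCCCCCNC(=O)[C@H](CO)/N=C/c1ccccc1Cl` gives 10300 nM in a functional assay on cells (Homo sapiens) for cytotoxicity, read by MTT assay, with a stated time of 24 h (on this read-out higher numbers stand for weaker inhibition and lower numbers for stronger inhibition), and holds the lowest of the three numbers. Compound 1 `CCCCCCCCCCCCCCNC(=O)[C@H](CO)NCc1ccccc1O` reads 75300 nM and compound 3 `CCCCCCCCCCCCCCNC(=O)[C@H](CO)NCc1ccccc1OC` reads 100000 nM in this assay with no order between them. Compound 4 `CCCCCCCCCCCCCCNC(=O)[C@H](CO)/N=C/c1ccc([N+](=O)[O-])cc1` follows from compound 2 by 4-nitrophenyl in place of 2-chlorophenyl on a carbon with a double bond to nitrogen with 4-nitrophenyl in place of 2-chlorophenyl on a carbon with a double bond to nitrogen. Going by the values given here, no measured step makes this change directly. The larger steps of a 7.3-fold lower number from compound 1 to compound 2 (0.86 log units; beyond the scatter) and a 9.7-fold higher number from compound 2 to compound 3 (0.99 log units; beyond the scatter) also alter the bond to nitrogen and so bear on it only loosely. Among the compounds with values here, the one change confined to the ring is a 1.3-fold higher number from compound 1 to compound 3 (0.12 log units; within the scatter) and it stays within the scatter. The expected step is a 1.4-fold higher number from compound 2 to compound 4 (0.13 log units; within the scatter) and no shift beyond the scatter is expected in this assay for this swap. Compound 4 is estimated at 14000 nM with 5000 nM to 45000 nM as the expected range.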

Compound 4, half-maximal inhibitory concentration: 217000 nM
The estimate for compound 4 lay 16-fold (1.19 log units) below the measured number, outside the stated range (above it).
By their numbers in this assay, from the lowest: compound 2; then compounds 1 and 3 (each within the scatter of the next); then compound 4.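

On a carbon with a double bond to nitrogen, 4-nitrophenyl in place of 2-chlorophenyl gives a 21-fold higher number from compound 2 to compound 4 (1.32 log units; beyond the scatter) in this assay. Going by these compounds alone, the aryl group at this place can therefore shift the read-out strongly with the rest of the molecule unchanged, which the one earlier change confined to the ring, within the scatter, did not show. Nothing available explains this shift.

From the compounds shown here alone, this step replaces the ring substituent and alters its ring position together, so their separate contributions remain open. Neither 4-chlorophenyl nor 2-nitrophenyl is among the compounds shown, and either would help separate them.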